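Swapping the amidine end group of a benzofuran series

The compounds below may be only part of what the source reports. "The series", "measured", "known", "first", "only" and "open" are said of these compounds alone.

Measured compounds:
compound 1, `c1ccc(OCCCOc2cccc(-c3cc4ccc(C5=NCCN5)cc4o3)c2)cc1`, 10100 nM;
compound 2, `N=C(N)c1ccc2cc(-c3cccc(OCCCCOc4ccccc4)c3)oc2c1`, 7600 nM;
compound 3, `CC(C)NC(=N)c1ccc2cc(-c3cccc(OCCCCOc4ccccc4)c3)oc2c1`, 46500 nM.

In an ADME assay on L6 cells (Rattus norvegicus) for cytotoxicity, read by resazurin assay, with a stated time of 70 h (a lower number here means a stronger inhibitor, a higher number a weaker inhibitor), compound 3 stands at the highest of the three numbers; its nearest neighbour is compound 1 and its furthest is compound 2, and both steps toward it are beyond the scatter. Among the measured compounds shown here, the one measured step that differs in a single place, a 6.1-fold higher number from compound 2 to compound 3 (0.79 log units; beyond the scatter), is the only step on record, a modest one.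

Compound 4, `c1ccc(OCCCCOc2cccc(-c3cc4ccc(C5=NCCN5)cc4o3)c2)cc1`, arises from compound 3 by the change (a group of 5 heavy atoms (3 carbon, 2 nitrogen; one five-membered non-aromatic ring with 2 hetero atoms) in place of a group of 6 heavy atoms (4 carbon, 2 nitrogen; no ring), on an aromatic carbon). For the measured compounds named here, no measured pair shows this exact swap. What bears on it is the step from compound 2 to compound 3, in which the isopropyl entering an amine nitrogen raised the number; compound 4 carries no such isopropyl. The ring-bearing group that enters compound 4 is the same one carried by compound 1, and compound 1 gives 10100 nM in this assay.

Compound 4 is therefore expected to give a lower number than compound 3, with the step of a 4.2-fold lower number from compound 3 to compound 4 (0.63 log units; beyond the scatter), because compound 1 gives 10100 nM with that group in place. The estimate for compound 4 is 11000 nM, within a range from 4000 nM to 35000 nM.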

Compound 4, half-maximal inhibitory concentration: 5800 nM
Estimate against measurement, compound 4: 1.9-fold (0.28 log units) above; measured number inside the range.
By their numbers in this assay, from the lowest: compounds 4, 2 and 1 (each within the scatter of the next); then compound 3.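

In this assay, the five-membered ring group on the aromatic carbon lies far from the open isopropyl-bearing group of compound 3 (an 8.0-fold lower number from compound 3 to compound 4 (0.90 log units; beyond the scatter)), but it cannot be told apart from the smaller open group of compound 2 (a 1.3-fold lower number from compound 2 to compound 4 (0.12 log units; within the scatter)), so among these three end groups only the one carrying the isopropyl stands apart. Among the compounds shown here, with the ring group held in place, phenoxymethyl in place of phenoxy on the saturated chain also leaves the number within the scatter (a 1.7-fold lower number from compound 1 to compound 4 (0.24 log units; within the scatter)), so this chain change gives no measurable step in these two compounds. Nothing given here offers a measured reason for the high number of compound 3 or for the closeness of the other three. The compounds shown leave open whether the step on the amine nitrogen is specific to isopropyl or would also appear with a methyl or a cyclopentyl, and whether a six-membered ring with the same two nitrogens would match the five-membered ring group. They also leave open how a longer chain would read with either end group, and whether a carboxylic acid on that aromatic carbon would fall with compound 3 or with the others.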